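Pyridine for Thiophene, Carried onto a Piperidine Core

The compounds below may be only part of what the source reports. "The series", "measured", "known", "first", "only" and "open" are said of these compounds alone.

Compound 1, `c1cncc(-c2ccnc(Nc3ccc(-n4ccnc4)cc3)n2)c1`: 1300 nM
Compound 2, `c1csc(-c2ccnc(Nc3ccc(-n4ccnc4)cc3)n2)c1`: 4300 nM
Compound 3, `CC1CCN(c2ccc(Nc3nccc(-c4cccs4)n3)cc2)CC1`: 400 nM

Of the compounds shown here, three have been measured in a functional assay for inhibition, with Homo sapiens as the target; on this read-out higher numbers stand for weaker inhibition and lower numbers for stronger inhibition. Compound 2 stands with 4300 nM, the highest of the three numbers. Two single changes to compound 2 are on record. The first is pyridin-3-yl in place of thiophen-2-yl on an aromatic carbon, which gave a 3.3-fold lower number from compound 2 to compound 1 (0.52 log units; beyond the scatter). The second is 4-methylpiperidin-1-yl in place of 1H-imidazol-1-yl on an aromatic carbon, which gave an 11-fold lower number from compound 2 to compound 3 (1.03 log units; beyond the scatter) and left compound 3 with the lowest number of the three.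

Compound 4, `CC1CCN(c2ccc(Nc3nccc(-c4cccnc4)n3)cc2)CC1`, has not yet been measured in this assay. It differs from compound 3 by pyridin-3-yl in place of thiophen-2-yl on an aromatic carbon. This is the same change that was made from compound 2 to compound 1, and it sits at the same place; the two cores differ by the exchange described for compound 2 and compound 3, with 4-methylpiperidin-1-yl in place of 1H-imidazol-1-yl on an aromatic carbon.

Going by the values given here, with only one earlier instance of this change, on a different core, the account expects the step from compound 3 to compound 4 to be about a 2.7-fold lower number from compound 3 to compound 4 (0.43 log units; beyond the scatter), a step of roughly the size seen as a 3.3-fold lower number from compound 2 to compound 1 (0.52 log units; beyond the scatter), because compound 3 already gives 400 nM and the earlier step was modest. Compound 4 is therefore expected to give about 150 nM in this assay, estimated to fall between 50 nM and 450 nM.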

Compound 4, half-maximal inhibitory concentration: 500 nM
For compound 4 the middle estimate is 3.3-fold (0.52 log units) below the measured one, outside the stated range (above it).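

In this assay, pyridin-3-yl in place of thiophen-2-yl on the core of compound 3 gave a 1.3-fold higher number from compound 3 to compound 4 (0.10 log units; within the scatter), so compound 3 and compound 4 stand within the scatter of each other and the step seen on the core of compound 2 did not carry over: the same change on two cores in this assay, a 3.3-fold lower number (0.52 log units; beyond the scatter) from compound 2 to compound 1 and a 1.3-fold higher number (0.10 log units; within the scatter) from compound 3 to compound 4, 4.1-fold (0.62 log units) apart, beyond the scatter of two such steps

Read the other way round, 4-methylpiperidin-1-yl in place of 1H-imidazol-1-yl still gave a 2.6-fold lower number from compound 1 to compound 4 (0.41 log units; beyond the scatter), yet this step too differs from its earlier counterpart: the same change on two cores in this assay, an 11-fold lower number (1.03 log units; beyond the scatter) from compound 2 to compound 3 and a 2.6-fold lower number (0.41 log units; beyond the scatter) from compound 1 to compound 4, 4.1-fold (0.62 log units) apart, beyond the scatter of two such steps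

The four compounds thus show that the two changes do not simply add up in this series, but they give no reason for this and cannot tell how pyridin-3-yl would behave on any third core.

The compounds shown leave open whether the result depends on ring size or on the kind of hetero atom, since thiophen-2-yl and pyridin-3-yl differ in both; a furan-2-yl or a plain phenyl group at the same place would bear on this. On these data alone, it also remains open whether a morpholine in place of 4-methylpiperidin-1-yl would keep the step from the core of compound 1 or alter it again.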